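From a methylphenyl to a methylindolyl arm

The source may report more compounds than this note shows. Statements on the series, on what has been measured and on what is new or still open speak of the compounds shown alone.

Compound 1 `COc1cc(-c2ccnc3cc(-c4ccc(C)cc4)nn23)cc(OC)c1OC` is the reference point of this small series. In a functional assay on HeLa cells (Homo sapiens) for inhibition, read by CCK-8 assay, with a stated time of 48 h (on this read-out lower numbers stand for stronger inhibition and higher numbers for weaker inhibition), compound 1 gives 21 nM, the lowest of the three numbers recorded. Compound 2 `COc1cc(-c2ccnc3cc(-c4ccc(C(C)=O)cc4)nn23)cc(OC)c1OC` carries an acetyl in place of the methyl and gives 1810 nM, while compound 3 `COc1cc(-c2ccnc3cc(-c4ccc(N(C)C)cc4)nn23)cc(OC)c1OC` carries a dimethylamino there and gives 378 nM. Both steps from compound 1 are large: an 86-fold higher number from compound 1 to compound 2 (1.94 log units; beyond the scatter) and an 18-fold higher number from compound 1 to compound 3 (1.26 log units; beyond the scatter). Between them, a 4.8-fold lower number from compound 2 to compound 3 (0.68 log units; beyond the scatter).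

Compound 4 `COc1cc(-c2ccnc3cc(-c4cn(C)c5ccccc45)nn23)cc(OC)c1OC` has not yet been measured. It differs from compound 1 by 1-methyl-1H-indol-3-yl in place of 4-methylphenyl on an aromatic carbon, a wider change than the swaps that produced compounds 2 and 3. The two measured steps from compound 1 both point the same way, toward a higher number whenever the methyl is replaced, so a higher number is expected for compound 4 as well. The estimate for compound 4 in this assay is 150 nM, within a range from 30 nM to 900 nM, which corresponds to an expected step of a 7.1-fold higher number from compound 1 to compound 4 (0.85 log units; beyond the scatter).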

Compound 4, half-maximal inhibitory concentration: 399 nM
The estimate for compound 4 lay 2.7-fold (0.42 log units) below the measured number; the range from low to high includes it.
By their numbers in this assay, from the lowest: compound 1; then compounds 3 and 4 (each within the scatter of the next); then compound 2.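

Exchanging the whole 4-methylphenyl for 1-methyl-1H-indol-3-yl, and not only its methyl, also gives a large rise in this assay (a 19-fold higher number from compound 1 to compound 4 (1.28 log units; beyond the scatter)). The arm with two aromatic rings and a nitrogen sits level with the 4-(dimethylamino)phenyl arm (a 1.1-fold higher number from compound 3 to compound 4 (0.02 log units; within the scatter)) and clear of the 4-acetylphenyl arm (a 4.5-fold lower number from compound 2 to compound 4 (0.66 log units; beyond the scatter)), so among these four compounds the low number stays with the 4-methylphenyl of compound 1 alone. No supporting data bear on what lies behind these differences.

From the compounds shown here alone, it remains open whether the rise in compound 4 follows from the indole rings or from the methyl on their nitrogen, which an indol-3-yl arm with a hydrogen on that nitrogen would address. Going by these compounds, how narrow the demand at this position is also stays open, since an ethyl or a methoxy in place of the methyl on the phenyl arm could test it.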